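The compounds below may be only part of what the source reports. "The series", "measured", "known", "first", "only" and "open" are said of these compounds alone.

A set of compounds sharing one core has been tested in a functional assay on MCF7 cells (Homo sapiens) for antiproliferative activity, read by MTT assay, with a stated time of 24 h (a lower number here means a stronger inhibitor, a higher number a weaker inhibitor), so far. Compound 1 (`CNC(=O)c1ccccc1Oc1nc(Nc2cccc(C)c2)ncc1Br`) gives a value of (16600 nM). Compound 2 (`Cc1cccc(Nc2ncc(Br)c(Oc3cccc(F)c3)n2)c1`) gives a value of (26800 nM). These two numbers lie within the usual scatter of each other, so compound 2 cannot be ranked apart from compound 1. Compound 3 (`Cc1cccc(Nc2ncc(Br)c(Oc3cccc([N+](=O)[O-])c3)n2)c1`) has only a limit (> 50000 nM), not a number.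

The compound still to be measured is compound 4 (`Cc1cccc(Nc2ncc(Br)c(Oc3ccc(Br)cc3)n2)c1`). Compared with compound 2, it carries 4-bromophenyl in place of 3-fluorophenyl on an oxygen on an aromatic ring. Going by the values given here, only one measured step touches this same group, the swap of nitro for fluoro. That step is an at least 1.8-fold higher number from compound 2 to compound 3 (0.27 log units; that floor lies within the scatter) and it gives a floor, not a true size. It offers little guidance on how far a change at this group can move the number, and it involves a different substituent. Among the compounds with values here, with only this step to go on, no shift beyond the scatter is expected in this assay, and no direction can be favoured with confidence. The expected step is small (a 1.1-fold lower number from compound 2 to compound 4 (0.03 log units; within the scatter)). Compound 4 is estimated at (25000 nM), with an expected range from 10000 nM to (50000 nM).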

Compound 4, half-maximal inhibitory concentration: 19100 nM
Beside the measured number, compound 4's estimate is 1.3-fold (0.12 log units) above it; the range from low to high includes it.
By their numbers in this assay, from the lowest: compounds 1, 4 and 2 (each within the scatter of the next). At a limit, above all of these: compound 3.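

Swapping 3-fluorophenyl for 4-bromophenyl on the oxygen gives the only step at this position in this assay with a true number at both ends (a 1.4-fold lower number from compound 2 to compound 4 (0.15 log units; within the scatter)). The earlier nitro swap gave only a floor, whereas this step has a real size, and that size lies within the scatter, so the two compounds cannot be ranked apart. The leaving and entering groups have equal heavy-atom counts and each is a carbon-only aromatic ring carrying one halogen, but the halogen and its place on the ring change together, so this single step cannot separate the two changes.

Compound 3 still has only a limit, not a number: (the limit of > 50000 nM in this assay, at which 1 of the 4 values shown sits). The compounds shown do not tell how an amine or a carboxylic acid on this ring would read, or a longer chain in place of the ring, so how far a change at this position can move the number remains open.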